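Replacing 6-bromohexyl with benzyl on the shared core

This account rests on a few compounds, and the source may have more. Where it says the series, first, only, none or still open, it means among the compounds named here.

compound 1 `Brc1ccc(Oc2cc(Br)cc(Br)c2OCCCCCN2CCN(c3ccccc3)CC2)c(Br)c1` gives 42.5 ug/mL
compound 2 `BrCCCCCCOc1c(Br)cc(Br)cc1Oc1ccc(Br)cc1Br` gives 33.8 ug/mL
compound 3 `COc1ccccc1N1CCN(CCCCCOc2c(Br)cc(Br)cc2Oc2ccc(Br)cc2Br)CC1` gives 37.5 ug/mL

These three values come from a functional assay on U-937 cells (Homo sapiens) for cytotoxicity, read by MTT assay, with a stated time of 24 h (a lower number here means a stronger inhibitor, a higher number a weaker inhibitor), and sit close together. Compound 2 (33.8 ug/mL) lies within the scatter of both compound 1 and compound 3, so it holds no separate place among them.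

Compound 4 `Brc1ccc(Oc2cc(Br)cc(Br)c2OCc2ccccc2)c(Br)c1` has not yet been measured in this assay. It differs from compound 2 in one place, with phenyl in place of 5-bromopentyl on a saturated chain carbon bound to an oxygen on an aromatic ring and the rest of the structure unchanged.

Within the data shown here, only one measured step exists, a 1.1-fold lower number from compound 1 to compound 3 (0.05 log units; within the scatter), which is a methoxy in place of hydrogen on an aromatic carbon and stays within the scatter. It is a different change and bears only indirectly on this one. Among the measured compounds shown here, no measured compound carries a benzyl group, so the data give no direction for the replacement. The closest guide is that compound 1, with a very different group at the end of its chain, gives 42.5 ug/mL and remains within the scatter of compound 2.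

The estimated change a 1.1-fold higher number from compound 2 to compound 4 (0.03 log units; within the scatter) is therefore expected to stay within the scatter. Compound 4 is expected at 36 ug/mL, with an estimated range from 19 ug/mL to 65 ug/mL in the measurement to come.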

Compound 4, half-maximal inhibitory concentration: 29 ug/mL
Estimate against measurement, compound 4: 1.2-fold (0.09 log units) above, within the range that was stated.
By their numbers in this assay, from the lowest: compounds 4, 2, 3 and 1 (each within the scatter of the next).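

In this assay, the replacement of 5-bromopentyl by phenyl on a saturated chain carbon bound to an oxygen on an aromatic ring gives a 1.2-fold lower number from compound 2 to compound 4 (0.07 log units; within the scatter). Among these compounds, this is the first measured step at this place, as the only earlier step was a methoxy in place of hydrogen on an aromatic carbon elsewhere in the structure. A chain without a ring that carries bromine and a six-membered aromatic ring of carbon only therefore read alike here, and no measurement shown explains this likeness.

Among the compounds shown here, with only this one step at this place, it remains open whether any other group there would give a step beyond the scatter. A carboxylic acid, a primary amine or a plain methyl in place of 5-bromopentyl lies outside the compounds shown, as does a methoxy on the phenyl of the benzyl group, so the reach of this flat result over other groups at this place is unknown.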